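A few compounds are considered here, and "the series" means these few. Any claim that something is new, unique, unknown or untested is made for them only; others in the source may bear on it.

Three compounds of the series have been taken through an assay on nucleic acid for binding affinity to Salmon testes DNA (Salmonidae), tested at 10 uM (on this read-out higher numbers stand for stronger stabilisation of the target against heat and lower numbers for weaker stabilisation of the target), so far. Compound 1 `CC(C)CCc1sc(NC(=O)c2cc(NC(=O)c3cc(NC(=N)c4ccc(Cl)cc4)cn3C)cn2C)nc1C(=O)NCCCN(C)C` gives 4 degrees C in this assay, and compound 2 `CC(C)CCc1sc(NC(=O)c2cc(NC(=O)c3cc(NC(=N)c4cccc(F)c4)cn3C)cn2C)nc1C(=O)NCCCN(C)C` gives 4 degrees C; the one difference between them, 3-fluorophenyl in place of 4-chlorophenyl on a carbon with a double bond to nitrogen, gives no change at the digits printed from compound 1 to compound 2 (within the scatter). Compound 3 `CN(C)CCCNC(=O)c1cc(NC(=O)c2cc(NC(=O)c3cc(NC(=N)c4ccccc4)cn3C)cn2C)cn1C`, built on a different core, gives 11 degrees C and stands highest of the three, with its steps to compound 1 and to compound 2 both beyond the scatter.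

Compound 4 `COc1cccc(C(=N)Nc2cc(C(=O)Nc3cc(C(=O)Nc4cc(C(=O)NCCCN(C)C)n(C)c4)n(C)c3)n(C)c2)c1` is the next candidate and has not yet been measured in this assay. It differs from compound 3 in one place: methoxy in place of hydrogen on an aromatic carbon. For the measured compounds named here, no measured step changes exactly this position on the core of compound 3. Going by the values given here, the only step that touches the same aryl ring is the swap from compound 1 to compound 2, where a change of ring substituent gave no change at the digits printed from compound 1 to compound 2 (within the scatter). On that basis the methoxy is expected to leave the melting-temperature shift close to where compound 3 stands, with any step no change at the digits printed from compound 3 to compound 4 (within the scatter) expected to stay within the scatter. Compound 4 is therefore estimated at 11 degrees C in this assay, with a range from 8 degrees C to 14 degrees C.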

Compound 4, shift of the target's melting temperature: 11 degrees C
Estimate against measurement, compound 4: no gap at the digits printed; low and high end bracket the measured number.
By their numbers in this assay, from the lowest: compounds 1 and 2 (each within the scatter of the next); then compounds 3 and 4 (each within the scatter of the next).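

In this assay, methoxy in place of hydrogen on an aromatic carbon, meta to a large group, gives no change at the digits printed from compound 3 to compound 4 (within the scatter) on the core of compound 3, so this position takes a first substituent on the plain phenyl without a step that stands out from the scatter. The earlier reading on this ring, no change at the digits printed from compound 1 to compound 2 (within the scatter) in the same assay, concerned only the exchange of one ring substituent for another on a different core, and it said nothing about phenyl itself or about the core of compound 3. No supporting data accompany these compounds to explain why the reading holds at this position.

The compounds shown test only methoxy at this place on the core of compound 3, so an amine, a carboxylic acid or a longer alkoxy chain on the same aromatic carbon remains an open case. Also open is whether the 3-methoxyphenyl group would read the same on the core of compound 1, where the ring substituents shown are different ones.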